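The compounds below may be only part of what the source reports. "The series", "measured", "known", "first", "only" and "open" are said of these compounds alone.

Measured so far in an ADME assay on HepG2 cells (Homo sapiens) for cytotoxicity, with a stated time of 48 h; a lower number here means a stronger inhibitor, a higher number a weaker inhibitor: compound 1 `O=[N+]([O-])c1cc(-c2nnc(SCc3ccc(Cl)c(Cl)c3)n2Cc2ccccc2)cc([N+](=O)[O-])c1` gives > 30000 nM, which is a limit of the assay and not a number. Compound 2 `COc1ccc(CSc2nnc(-c3cc([N+](=O)[O-])cc(C(F)(F)F)c3)n2Cc2ccccc2)cc1` gives > 30000 nM, again a limit. Compound 3 `O=[N+]([O-])c1cc(-c2nnc(SCc3ccc(Cl)cc3)n2Cc2ccccc2)cc(C(F)(F)F)c1` gives > 30000 nM, likewise a limit.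

Compound 3 therefore stands at the assay limit, the place described by the limit of > 30000 nM in this assay, at which 3 of the 3 values shown sit, where every value shown sits. Compound 4 `O=[N+]([O-])c1cc(-c2nnc(SCc3ccc(Cl)c(Cl)c3)n2Cc2ccccc2)cc(C(F)(F)F)c1` differs from compound 3 by chloro in place of hydrogen on an aromatic carbon. Going by the values given here, the only measured step, a step that the two limits leave unreadable from compound 2 to compound 3, runs between two limits and has no readable size. Compound 1, which carries the same 3,4-dichlorobenzyl group as compound 4, also sits at the limit. The step that the limit leaves unreadable from compound 3 to compound 4 is therefore expected to show nothing beyond the scatter, most likely another limit. Compound 4 is estimated at 60000 nM, within 20000 nM to 300000 nM.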

Compound 4, half-maximal inhibitory concentration: > 30000 nM
Compound 4: only a limit was reported; the forecaster's own chance of this, stated with the estimate: 90%; the middle value lies beyond the limit too.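

In this assay compound 4 gives > 30000 nM, a limit and not a number, so its steps from compound 1, compound 2 and compound 3 cannot be read. The compounds shown leave open whether these four differ at all in this read-out.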